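This account rests on a few compounds, and the source may have more. Where it says the series, first, only, none or still open, it means among the compounds named here.

Compound 1 `COc1ccc(/C=C/C(=O)c2c(C)[n+]([O-])c3ccccc3[n+]2[O-])cc1` and compound 2 `Cc1c(C(=O)/C=C/c2ccc(Cl)c(Cl)c2)[n+]([O-])c2ccccc2[n+]1[O-]` share one core and differ only in the aryl group on the double-bonded chain carbon. In a functional assay on HSC-2 cells (Homo sapiens) for cytotoxicity, with a stated time of 48 h (a lower number here means that less compound is tolerated, a higher number that more compound is tolerated), compound 1 gives 20000 nM, and compound 2 gives 17000 nM. Of the two numbers measured, compound 2 sits at the foot, but the step of a 1.2-fold lower number from compound 1 to compound 2 (0.07 log units; within the scatter) is within the scatter, so the two compounds cannot be told apart on this evidence.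

Compound 3 `Cc1ccc(/C=C/C(=O)c2c(C)[n+]([O-])c3ccccc3[n+]2[O-])cc1` is the next member of the series. It differs from compound 2 by 4-methylphenyl in place of 3,4-dichlorophenyl on a double-bonded chain carbon bound to a double-bonded chain carbon. Within the data shown here, the only measured step that bears on this change is the one at the same place, from compound 1 to compound 2, which swapped one aryl group for another and gave a 1.2-fold lower number from compound 1 to compound 2 (0.07 log units; within the scatter), a step within the scatter. Among the measured compounds shown here, with only that single precedent, the expectation is that the change to 4-methylphenyl likewise produces no step beyond the scatter, so the estimated step is a 1.1-fold higher number from compound 2 to compound 3 (0.05 log units; within the scatter). On that basis compound 3 is expected to give 19000 nM in this assay, with an estimated range from 8000 nM to 45000 nM.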

Compound 3, half-maximal cytotoxic concentration: 8400 nM
Compound 3: middle estimate off by 2.3-fold (0.35 log units), on the high side; measured number inside the range.
By their numbers in this assay, from the lowest: compound 3; then compounds 2 and 1 (each within the scatter of the next).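

In this assay the aryl group on this double-bonded chain carbon proves able to shift the number: 4-methylphenyl in place of 3,4-dichlorophenyl gives a 2.0-fold lower number from compound 2 to compound 3 (0.31 log units; beyond the scatter) and, in the comparison with the methoxy compound, methyl in place of methoxy on an aromatic carbon gives a 2.4-fold lower number from compound 1 to compound 3 (0.38 log units; beyond the scatter) as a modest change beyond the scatter, whereas the earlier step at this place, a 1.2-fold lower number from compound 1 to compound 2 (0.07 log units; within the scatter), did not separate its two compounds. Compound 3 therefore stands apart from both compound 1 and compound 2, which remain within the scatter of each other, so a swap of one aryl group for another here cannot be assumed to leave the number unchanged. Nothing available explains why the 4-methylphenyl group gives the lowest number of the three.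

Among these compounds, with only three aryl groups in view, it remains open whether the separation belongs to the methyl group itself or merely to the loss of the alternatives. An ethyl group in place of that methyl, or an amine or a carboxylic acid on the same aromatic carbon, would show whether the number moves further or returns to the level of compound 1 and compound 2.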